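Swapping the aryl on the double-bonded ring carbon

The source may hold more compounds than are shown below. What is called first, only, known or untested is meant among the compounds shown, and "the series" means these compounds.

Measured so far:
compound 1 `COc1ccc(C2=C(c3ccc(SC)cc3)CC3CCCN3C2=O)cc1Br` gives 3000 nM
compound 2 `CSc1ccc(C2=C(c3ccc(C)c(C)c3)C(=O)N3CCCC3C2)cc1` gives 300 nM
compound 3 `COc1ccc(C2=C(c3ccc(SC)cc3)CC3CCCN3C2=O)cc1OC` gives 9000 nM

In a functional assay on SK-OV-3 cells (Homo sapiens) for cytotoxicity (on this read-out lower numbers stand for stronger inhibition of growth and higher numbers for weaker inhibition of growth), compound 1 stands second highest of the three numbers; its nearest neighbour is compound 3, its furthest compound 2. The steps run a 3.0-fold higher number from compound 1 to compound 3 (0.48 log units; beyond the scatter) and a 10-fold lower number from compound 1 to compound 2 (1.00 log units; beyond the scatter).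

Compound 4 `CSc1ccc(C2=C(c3ccc(SC)cc3)C(=O)N3CCCC3C2)cc1` is not yet measured. Relative to compound 1 the change is 4-(methylsulfanyl)phenyl in place of 3-bromo-4-methoxyphenyl on a double-bonded ring carbon. Both measured steps touch the same ring: replacing the whole 3-bromo-4-methoxyphenyl gave the large drop to compound 2, while exchanging only the bromo gave the rise to compound 3. A second 4-(methylsulfanyl)phenyl is expected to behave more like the step to compound 2, so a modest lowering beyond the scatter is expected, a 5.0-fold lower number from compound 1 to compound 4 (0.70 log units; beyond the scatter). For compound 4 the estimate is 600 nM, between 150 nM and 2500 nM.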

Compound 4, concentration for 50% growth inhibition: 2000 nM
Compound 4: the middle estimate sits 3.3-fold (0.52 log units) below what was measured; measured number inside the range.
By their numbers in this assay, from the lowest: compound 2; then compounds 4 and 1 (each within the scatter of the next); then compound 3.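

In this assay, 4-(methylsulfanyl)phenyl on the double-bonded ring carbon gives a 1.5-fold lower number from compound 1 to compound 4 (0.18 log units; within the scatter) and so leaves compound 4 level with compound 1, while a 6.7-fold higher number from compound 2 to compound 4 (0.82 log units; beyond the scatter) sets it apart from the 3,4-dimethylphenyl compound. Losing 3-bromo-4-methoxyphenyl from this position is therefore not enough on its own, and among the replacements shown only 3,4-dimethylphenyl, in compound 2, stands apart. Nothing at hand explains the difference between these two replacements. Open, from the compounds shown here alone, is whether a single methyl group on this aryl would match compound 2, and how an aryl bearing an amine or a carboxylic acid would behave here.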